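A Second Methyl on the 4-Methylphenyl Group

This account rests on a few compounds, and the source may have more. Where it says the series, first, only, none or still open, it means among the compounds named here.

Three compounds have been measured:
Compound 1, `COc1cccc(C(=O)Nc2cc(-c3ccccc3)nn2-c2ccccc2)c1`, gives 1290 nM in an assay on HEK293 cells for displacement of a labelled ligand from metabotropic glutamate receptor 5 (Rattus norvegicus); a higher number here means a weaker inhibitor, a lower number a stronger inhibitor.
Compound 2, `O=C(Nc1cc(-c2ccccc2)nn1-c1ccccc1)c1cccc([N+](=O)[O-])c1`, gives 2220 nM in this assay.
Compound 3, `Cc1ccc(C(=O)Nc2cc(-c3ccccc3)nn2-c2ccccc2)cc1`, gives 780 nM in this assay.

All three share the same core and differ only in the aryl group on the carbonyl carbon. Compound 3 has the lowest number of the three, but its distance to compound 1 is small: a 1.7-fold lower number from compound 1 to compound 3 (0.22 log units; within the scatter). Only against compound 2 is the gap larger: a 2.8-fold lower number from compound 2 to compound 3 (0.45 log units; beyond the scatter). The swap of substituents on that aryl group between compound 1 and compound 2 also stayed small: a 1.7-fold higher number from compound 1 to compound 2 (0.24 log units; within the scatter).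

Compound 4, `Cc1ccc(C(=O)Nc2cc(-c3ccccc3)nn2-c2ccccc2)cc1C`, takes one further step on the same aryl group: methyl in place of hydrogen on an aromatic carbon. For the measured compounds named here, none of the measured steps adds a second substituent of this kind, so the nearest guidance is that every change on this aryl group so far has moved the number by little, at most a modest amount. An added methyl is expected to behave the same way, giving a change in this assay that does not clearly exceed the scatter in either direction: a 1.1-fold lower number from compound 3 to compound 4 (0.05 log units; within the scatter). Compound 4 is therefore estimated at 700 nM, with a likely range from 300 nM to 1800 nM.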

Compound 4, inhibition constant: 430 nM
Compound 4: the middle estimate sits 1.6-fold (0.21 log units) above what was measured, within the range that was stated.
By their numbers in this assay, from the lowest: compounds 4, 3, 1 and 2 (each within the scatter of the next, the first and the last beyond it).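

For the compounds shown here, compound 4 is the first compound here with two substituents on this aryl group, and in this assay the methyl ortho to the existing methyl group is tolerated: the step stays within the scatter (a 1.8-fold lower number from compound 3 to compound 4 (0.26 log units; within the scatter)). The 3,4-dimethylphenyl group does, however, stand clearly apart from the 3-methoxyphenyl group (a 3.0-fold lower number from compound 1 to compound 4 (0.48 log units; beyond the scatter)), a separation that the 4-methylphenyl group of compound 3 did not reach, and also from the 3-nitrophenyl group (a 5.2-fold lower number from compound 2 to compound 4 (0.71 log units; beyond the scatter)). Nothing available explains these numbers.

Still open, from the compounds shown here alone, is whether a longer chain such as ethyl on the same aromatic carbon would stay within the scatter of compound 3, or whether it would move the number beyond it as far as the gaps seen here. The same question stands for an amine, a hydroxyl group or a carboxylic acid at that place, so one tolerated methyl says little about how much other groups can change the result in this assay.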